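Working notes: from compound 2 to compound 3

A few compounds are considered here, and "the series" means these few. Any claim that something is new, unique, unknown or untested is made for them only; others in the source may bear on it.

Measured in a physicochemical assay for solubility, read by HPLC, in phosphate buffer, at pH 6.5; a higher number here means a more soluble compound, a lower number a less soluble compound:
- compound 1 `COC(=O)C1=C(CN2CCNC(=O)C2)NC(c2nccs2)=NC1(C)c1ccc(F)cc1`: 34 ug/mL
- compound 2 `COC(=O)C1=C(CN2CCC(C(F)(F)F)C2)NC(c2nccs2)=NC1(C)c1ccc(F)cc1`: 13 ug/mL

Of these two, compound 2 has the lower number, at 13 ug/mL. Compound 3 `COC(=O)C1=C(CN2CCCS2(=O)=O)NC(c2nccs2)=NC1(C)c1ccc(F)cc1` keeps the shared core and differs from compound 2 in one group: a group of 7 heavy atoms (3 carbon, 1 nitrogen, 2 oxygen, 1 sulfur; one five-membered non-aromatic ring with 2 hetero atoms) in place of a group of 9 heavy atoms (5 carbon, 1 nitrogen, 3 fluorine; one five-membered non-aromatic ring with 1 hetero atom), on a saturated chain carbon bound to a double-bonded ring carbon.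

Among the measured compounds shown here, only one measured step bears on this change: a 2.6-fold lower number from compound 1 to compound 2 (0.42 log units; beyond the scatter). That step is modest but beyond the scatter, and it ends in the same 3-(trifluoromethyl)pyrrolidin-1-yl group that is given up here. For the measured compounds named here, the group in compound 1 and the group entering in compound 3 both carry oxygen and no fluorine, but they are different groups, and no measured compound holds the group entering here. One step is thin ground for any expectation.

A step of similar modest size towards a higher number in this assay is expected, estimated as a 2.3-fold higher number from compound 2 to compound 3 (0.36 log units; beyond the scatter). For compound 3 the estimated value is 30 ug/mL, with an expected range of 12 ug/mL to 75 ug/mL.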

Compound 3, solubility: 125 ug/mL
The estimate for compound 3 lay 4.2-fold (0.62 log units) below the measured number; measured number outside the range, above it.
By their numbers in this assay, from the lowest: compound 2; then compound 1; then compound 3.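

At the saturated chain carbon bound to a double-bonded ring carbon, the earlier pair showed only a modest spread in this assay; the ring carrying sulfur and two oxygens now gives a much larger change, a 9.6-fold higher number from compound 2 to compound 3 (0.98 log units; beyond the scatter), when it replaces 3-(trifluoromethyl)pyrrolidin-1-yl. The gain is not confined to the comparison with the fluorinated group, since the same ring also gives a 3.7-fold higher number from compound 1 to compound 3 (0.57 log units; beyond the scatter), so 3-oxopiperazin-1-yl does not mark the top of the range at this position among these three compounds. The data offer no measurement that accounts for either step, and the result stands here without an explanation.

The compounds shown leave open which feature of the entering ring goes with the higher number, as the steps change several atoms at once and no compound separates the sulfur and its two oxygens from the ring that holds them. On these data alone, an open-chain sulfonamide, a six-membered ring holding the same sulfur and oxygens, or a morpholine ring at this position would each begin to separate these features, and the effect of a carboxylic acid there also remains unknown.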